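Aryl swap on the ethenyl arm of compound 1

A few compounds are considered here, and "the series" means these few. Any claim that something is new, unique, unknown or untested is made for them only; others in the source may bear on it.

Compound 1 `COC(=O)/C=C/c1cccc(N(Cc2ccc(/C=C/c3ccccn3)cc2)C(=O)C2CCCCC2)c1` serves as the reference point of the series. In an assay on isolated protein with Bile acid receptor (Homo sapiens) as the target (on this read-out lower numbers stand for an effect already at smaller amounts and higher numbers for an effect only at larger amounts of compound), compound 1 gives 309 nM, the lowest of the two numbers shown, with compound 2 `COC(=O)/C=C/c1cccc(N(Cc2ccc(/C=C/c3ccccn3)cc2)C(=O)C(C)C)c1` nearest to it: in this assay compound 2 gives 310 nM, and the step of a 1.0-fold higher number from compound 1 to compound 2 (0.00 log units; within the scatter) lies within the scatter, so the two compounds sit together rather than in any order. Compound 3 `COC(=O)/C=C/c1cccc(N(Cc2ccccc2Br)C(=O)C2CCCCC2)c1` is reported in this assay only as a limit, > 1000 nM, with no number behind it. This is the limit of > 1000 nM in this assay, at which 1 of the 3 values shown sits.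

Compound 4 `COC(=O)/C=C/c1cccc(N(Cc2ccc(/C=C/c3ccc(OC)cc3)cc2)C(=O)C2CCCCC2)c1` has not yet been measured. It differs from compound 1 in one place: 4-methoxyphenyl in place of pyridin-2-yl on a double-bonded chain carbon bound to a double-bonded chain carbon. For the measured compounds named here, no measured step bears on this change: the single measured step, isopropyl in place of cyclohexyl on a carbonyl carbon, concerns a different place and was flat, and compound 3 replaces the whole benzyl arm at once, so its limit cannot be read as a step at the ethenyl position. No direction can be drawn from the numbers at hand, and the expectation therefore rests on compound 1 alone, with a wide range. Compound 4 is expected to give 300 nM, between 110 nM and 850 nM, in this assay. The step of a 1.0-fold lower number from compound 1 to compound 4 (0.01 log units; within the scatter) is accordingly expected to be none beyond the scatter.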

Compound 4, half-maximal effective concentration: 208 nM
Compound 4: the middle estimate sits 1.4-fold (0.16 log units) above what was measured; the range from low to high includes it.
By their numbers in this assay, from the lowest: compounds 4, 1 and 2 (each within the scatter of the next). At a limit, above all of these: compound 3.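

In this assay, for the compounds shown here, the exchange of pyridin-2-yl for 4-methoxyphenyl on the ethenyl arm gives a 1.5-fold lower number from compound 1 to compound 4 (0.17 log units; within the scatter), the first reading at this position. An aromatic ring of carbon only, carrying a methoxy group, therefore serves on this arm as well as the ring with a nitrogen, so the pyridine nitrogen is not needed to keep the number in this range, and the position accepts a larger group without a change beyond the scatter, just as the carbonyl substituent did with a 1.0-fold higher number from compound 1 to compound 2 (0.00 log units; within the scatter). Nothing measured here accounts for the result, and no cause can be assigned to the loss of the ring nitrogen or to the gain of the methoxy group.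

The change removes the nitrogen and adds the methoxy group in one step, so plain phenyl, or a pyridin-2-yl ring carrying a methoxy group, would be needed to read the two apart. Also open, going by these compounds, are a saturated ethyl link in place of the ethenyl link and a carboxylic acid in place of the methyl ester, on either the compound 1 or the compound 4 arm.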